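Swapping the Aromatic Group in a Weakly Active Series

The source may hold more compounds than are shown below. What is called first, only, known or untested is meant among the compounds shown, and "the series" means these compounds.

Compound 1 `C/C(=C\CC/C(C)=C/CC[C@@H]1[C@@]2(C)CCC(=O)C(C)(C)[C@H]2CC[C@@]1(C)O)CC/C=C(\C)C(=O)OCc1cn(C[C@@H]2O[C@H](n3ccc(=O)[nH]c3=O)[C@H]3OC(C)(C)O[C@H]32)nn1` gives 15300 nM in a functional assay on A549 cells (Homo sapiens) for antiproliferative activity, read by MTT assay, with a stated time of 48 h; a higher number here means a weaker inhibitor, a lower number a stronger inhibitor.
Compound 2 `C/C(=C\CC/C(C)=C/CC[C@@H]1[C@@]2(C)CCC(=O)C(C)(C)[C@H]2CC[C@@]1(C)O)CC/C=C(\C)C(=O)OCc1cn(-c2ccc([N+](=O)[O-])cc2)nn1` gives only the assay's limit, > 150000 nM.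
Compound 3 `C/C(=C\CC/C(C)=C/CC[C@@H]1[C@@]2(C)CCC(=O)C(C)(C)[C@H]2CC[C@@]1(C)O)CC/C=C(\C)C(=O)OCc1cn(-c2ccc(F)cc2)nn1` likewise gives only the limit, > 150000 nM.

Compound 2 thus stands at the weak end of what is shown, at a limit rather than at a number. The step that the two limits leave unreadable from compound 2 to compound 3 has no readable size, since both of its compounds sit at the limit of > 150000 nM in this assay, at which 2 of the 3 values shown sit. Compound 4 `C/C(=C\CC/C(C)=C/CC[C@@H]1[C@@]2(C)CCC(=O)C(C)(C)[C@H]2CC[C@@]1(C)O)CC/C=C(\C)C(=O)OCc1cn(-c2cccc(C(F)(F)F)c2)nn1` differs from compound 2 by 3-(trifluoromethyl)phenyl in place of 4-nitrophenyl on an aromatic nitrogen. Within the data shown here, the only measured step touching this same aromatic group, a step that the two limits leave unreadable from compound 2 to compound 3, yields no readable size, so no movement beyond the scatter is expected from a step that the limit leaves unreadable from compound 2 to compound 4. Compound 4 is therefore estimated at 200000 nM, within a range from 60000 nM to 700000 nM, and is expected most likely to come back again as a limit rather than a number.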

Compound 4, half-maximal inhibitory concentration: > 150000 nM
Compound 4: a limit, no number; the forecaster's own chance of this, stated with the estimate: 80%; the middle value is on the limit's open side.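

Compound 4 gives > 150000 nM, which is a limit and not a number. Among these compounds, no step among compound 2, compound 3 and compound 4 can therefore be read. The compounds shown leave open how far apart these three compounds truly lie in this assay.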